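The compounds below may be only part of what the source reports. "The series", "measured", "known", "first", "only" and "open" are said of these compounds alone.

Measured in a functional assay on HeLa S3 cells (Homo sapiens) for antiproliferative activity, read by XTT assay, with a stated time of 72 h; a higher number here means a weaker inhibitor, a lower number a stronger inhibitor:
- compound 1 `COc1ncnc2c1c(-c1cc3ccccc3o1)cn2[C@@H]1O[C@H](CO)[C@@H](O)[C@H]1O`: 9240 nM
- compound 2 `CSc1ncnc2c1c(-c1ccccc1)cn2[C@@H]1O[C@H](CO)[C@@H](O)[C@H]1O`: > 20000 nM
- compound 3 `CNc1ncnc2c1c(-c1ccco1)cn2[C@@H]1O[C@H](CO)[C@@H](O)[C@H]1O`: 5000 nM

The entry for compound 2 is a limit of this assay, not a number. Compound 3 at 5000 nM lies within the scatter of compound 1 at 9240 nM, so the two cannot be ranked.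

Compound 4 `C#Cc1cn([C@@H]2O[C@H](CO)[C@@H](O)[C@H]2O)c2ncnc(NC)c12` carries ethynyl in place of furan-2-yl on an aromatic carbon. For the measured compounds named here, no two measured compounds differ in one place, so the series offers no direct guide to this change. A modest shift towards a lower number in this assay is expected, though one within the scatter would be no surprise. The estimated 2.0-fold lower number from compound 3 to compound 4 (0.30 log units; within the scatter) is therefore uncertain. For compound 4 the expected value is 2500 nM, with an estimated range of 300 nM to 15000 nM.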

Compound 4, half-maximal inhibitory concentration: > 20000 nM
Compound 4 gave a limit, no number; the forecaster's own chance of this, stated with the estimate: 20%; middle value at least 8.0-fold (0.90 log units) from the limit.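

In this assay, for the compounds shown here, replacing furan-2-yl with ethynyl on this aromatic carbon gives the first single-place step: an at least 4.0-fold higher number from compound 3 to compound 4 (0.60 log units; beyond the scatter). Going by these compounds alone, at this position, then, the change goes towards weaker activity, beyond the scatter, which the earlier compounds could not show. Compound 4 stands at a limit, not a number, so the step gives only a lower bound on the change: the limit of > 20000 nM in this assay, at which 2 of the 4 values shown sit.

Going by these compounds, what a thiophen-2-yl or a longer alkynyl chain would give on this carbon in this assay remains open. On these data alone, whether the step holds with other groups elsewhere on the core is also open.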